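The source may hold more compounds than are shown below. What is called first, only, known or untested is meant among the compounds shown, and "the series" means these compounds.

Measured compounds:
Compound 1 `O=S(=O)(c1cc(Cl)cc(Cl)c1)c1cnc2cc(F)ccc2c1-c1ccc(F)cc1`: 0.18 mL/min
Compound 2 `O=S(=O)(c1cc(Cl)cc(Cl)c1)c1cnc2cc(F)ccc2c1-c1cccc(F)c1`: 0.41 mL/min

In an ADME assay on microsomes from liver (Homo sapiens) for metabolic stability, tested at 2.5 uM (a higher number here means faster removal of the compound, a lower number slower removal), compound 2 gives 0.41 mL/min, the higher of the two numbers measured. Among the measured compounds shown here, its only neighbour is compound 1, which gives 0.18 mL/min. For the measured compounds named here, the single measured step, a 2.3-fold higher number from compound 1 to compound 2 (0.36 log units; beyond the scatter), comes from moving the fluorine around the same ring and shows that a small change on that ring can shift the number by a modest amount.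

Compound 3 `COc1cccc(-c2c(S(=O)(=O)c3cc(Cl)cc(Cl)c3)cnc3cc(F)ccc23)c1` is built from compound 2 by a different kind of change: methoxy in place of fluoro on an aromatic carbon. Going by the values given here, no measured pair swaps fluoro for methoxy, so the step from compound 1 to compound 2 bears on it only loosely, as a sign of how much this position tolerates change without a large swing. With nothing closer to go on, the expectation for compound 3 is a small rise in this assay, a 1.5-fold higher number from compound 2 to compound 3 (0.17 log units; within the scatter), possibly still within the scatter. Compound 3 is therefore estimated at 0.6 mL/min, with a range from 0.25 mL/min to 1.4 mL/min.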

Compound 3, intrinsic clearance in a liver preparation (reported as CLH), per the amount of preparation that the assay uses: 1.51 mL/min
Estimate against measurement, compound 3: 2.5-fold (0.40 log units) below, and the stated range ends below it.
By their numbers in this assay, from the lowest: compound 1; then compound 2; then compound 3.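

Compound 1 and compound 2 showed only what happens when a fluorine moves around this ring, whereas compound 3 shows what happens when the group itself changes. In this assay, swapping fluoro for methoxy gives a 3.7-fold higher number from compound 2 to compound 3 (0.57 log units; beyond the scatter) and puts compound 3 at the top of the three, so this ring position responds clearly to the identity of its group, not only to where a fluorine sits. Taken against the 4-fluorophenyl compound, the 3-methoxyphenyl group gives an 8.4-fold higher number from compound 1 to compound 3 (0.92 log units; beyond the scatter) and is the widest step in this small set, though nothing available explains why the number moves in this way.

The compounds shown leave open whether the rise belongs to methoxy alone or would also appear with a longer chain such as ethoxy, an amine or a carboxylic acid on the same ring carbon. They also leave open whether methoxy would give a similar result in the place that the fluorine occupies in the 4-fluorophenyl group of compound 1.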